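The source may report more compounds than this note shows. Statements on the series, on what has been measured and on what is new or still open speak of the compounds shown alone.

Compound 2, with the structure `N#Cc1ccccc1-c1ccc(COc2ccc(/C=C3\SC(=O)NC3=O)cc2)cc1`, stands highest of the two compounds measured in a physicochemical assay for lipophilicity (a higher number here means a more lipophilic compound, a lower number a more polar compound), where compound 2 gives 4.94. Its nearest neighbour is compound 1, with the structure `Cc1ccc(COc2ccc(/C=C3\SC(O)=NC3=O)cc2)cc1`, and in this assay compound 1 gives 3.33, a gap well beyond the scatter of the measurement. The step now under consideration leads from compound 2 to compound 3, with the structure `O=C1NC(=O)/C(=C/c2ccc(OCc3ccc(Cl)cc3)cc2)S1`, which differs from compound 2 in one place: chloro in place of 2-cyanophenyl on an aromatic carbon. For the measured compounds named here, no measured pair in this set mirrors this exchange, so the size of the step has to be judged from the structures and from what compound 1 shows. Because compound 2 gives 4.94 while compound 1 gives 3.33, the chloro-bearing compound 3 is expected to fall between them, closer to compound 1. The expected step from compound 2 to compound 3 is a clear drop, estimated as a number 1.24 log units lower from compound 2 to compound 3 (beyond the scatter). For compound 3 the partition coefficient is therefore estimated at 3.7, with a likely range from 3.2 to 4.3.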

Compound 3, partition coefficient: 3.53
The estimate for compound 3 lay 0.17 log units above the measured number; the measured number falls inside the stated range.
By their numbers in this assay, from the lowest: compounds 1 and 3 (each within the scatter of the next); then compound 2.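

For the compounds shown here, the exchange of 2-cyanophenyl for chloro, on an aromatic carbon para to a large group, provides the first one-place comparison in this set: in this assay, it gives a number 1.41 log units lower from compound 2 to compound 3 (beyond the scatter), a large step. It shows that this position is not indifferent to what it carries, as the read-out moves well beyond the scatter when a group of 8 heavy atoms, including one six-membered aromatic ring and a nitrile, gives way to a single chlorine, and with this exchange compound 3 comes to stand within the scatter of compound 1. No measurement at hand accounts for the size of this step, so it stays an observation about this one pair.

As far as these compounds go, what remains open is how much of the step belongs to the aromatic ring and how much to the nitrile, a question that an unsubstituted phenyl at the same position would help to separate. From the compounds shown here alone, it is also open how the read-out at this position would respond to a group of a different kind, such as a carboxylic acid, an amine or a longer alkyl chain.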